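Urea to Amide Swap in a Melanoma Cell Growth Series

The source may hold more compounds than are shown below. What is called first, only, known or untested is meant among the compounds shown, and "the series" means these compounds.

Compound 1, `COc1cc(-c2nn(-c3cccc(NC(=O)c4cccc(C(F)(F)F)c4)c3)cc2-c2ccncc2)ccc1Cl`: in a functional assay on SK-MEL-5 cells (Homo sapiens) for inhibition, read by sulforhodamine B assay, with a stated time of 48 h (on this read-out higher numbers stand for weaker inhibition of growth and lower numbers for stronger inhibition of growth), compound 1 gives 978 nM.
Compound 2, `COc1cc(-c2nn(-c3cccc(NC(=O)Nc4ccc(Cl)c(Cl)c4)c3)cc2-c2ccncc2)ccc1Cl`: in this assay compound 2 gives 741 nM.
Compound 3, `COc1cc(-c2nn(-c3cccc(NC(=O)Nc4cccc(C(F)(F)F)c4)c3)cc2-c2ccncc2)ccc1Cl`: in this assay compound 3 gives 720 nM.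

All three measured compounds share one core and differ only in the group attached to the carbonyl carbon. Compound 3 has the lowest of the three numbers, but its gaps to the others are small: a 1.4-fold lower number from compound 1 to compound 3 (0.13 log units; within the scatter) and a 1.0-fold lower number from compound 2 to compound 3 (0.01 log units; within the scatter), both within the scatter, so no ordering among them can be claimed.

Compound 4, `COc1cc(-c2nn(-c3cccc(NC(=O)c4ccc(Cl)c(C(F)(F)F)c4)c3)cc2-c2ccncc2)ccc1Cl`, is not yet measured. It differs from compound 3 in one place: 4-chloro-3-(trifluoromethyl)phenyl in place of (3-(trifluoromethyl)phenyl)amino on a carbonyl carbon. The change reverses the step from compound 1 to compound 3 and adds a chlorine to the aryl ring. The step of a 1.4-fold lower number from compound 1 to compound 3 (0.13 log units; within the scatter) shows that trading an amide for a urea changed little; the step of a 1.3-fold lower number from compound 1 to compound 2 (0.12 log units; within the scatter) also stayed within the scatter. Within the data shown here, no measured pair shows the effect of adding the chlorine to an amide aryl. The expectation is therefore a step in this assay of a 1.3-fold higher number from compound 3 to compound 4 (0.10 log units; within the scatter), not beyond the scatter. Compound 4 is estimated at 900 nM, with a range from 450 nM to 1800 nM.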

Compound 4, concentration for 50% growth inhibition: 1380 nM
Beside the measured number, compound 4's estimate is 1.5-fold (0.19 log units) below it; the range from low to high includes it.
By their numbers in this assay, from the lowest: compounds 3, 2, 1 and 4 (each within the scatter of the next).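

In this assay, among these compounds, the added chloro on the aryl ring of the amide, a change no earlier pair covered, gives a 1.4-fold higher number from compound 1 to compound 4 (0.15 log units; within the scatter) and so stays inside the usual scatter. Among the compounds shown here, both a 1.9-fold higher number from compound 3 to compound 4 (0.28 log units; within the scatter) and a 1.9-fold higher number from compound 2 to compound 4 (0.27 log units; within the scatter) also stay within the scatter, though they are the largest steps so far, when 4-chloro-3-(trifluoromethyl)phenyl takes the place of a urea arm on the carbonyl carbon. Across all four compounds, then, this position has taken amide and urea arms, with and without the extra chloro, and no step has gone beyond the scatter.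

Going by these compounds, whether an amine, a carboxylic acid or a longer carbon chain in place of the aryl ring would move the number further remains open, as does a fluoro in place of the added chloro. No measurement at hand offers a reason for these small steps.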